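Aryl swap on an aromatic nitrogen: compound 3 to compound 4

The compounds below may be only part of what the source reports. "The series", "measured", "known", "first", "only" and "open" are said of these compounds alone.

Compound 1 `CCOc1ccccc1-n1nncc1CN1C(=O)C2(C(C#N)=C(N)Oc3c2c2nc4ccccc4nc2c2ccccc32)c2ccccc21` was tested in a functional assay on HepG2 cells (Homo sapiens) for antiproliferative activity, read by MTT assay, with a stated time of 48 h; a higher number here means a weaker inhibitor, a lower number a stronger inhibitor. In this assay compound 1 gives > 50000 nM, which is a limit of the assay and not a number. Compound 2 `Cc1ccc(C)c(-n2nncc2CN2C(=O)C3(C(C#N)=C(N)Oc4c3c3nc5ccccc5nc3c3ccccc43)c3ccccc32)c1` gives in this assay > 50000 nM, again only a limit. The step that the two limits leave unreadable from compound 1 to compound 2 therefore has no readable size. Compound 3 `N#CC1=C(N)Oc2c(N)cc3nc4ccccc4nc3c2C12C(=O)N(Cc1cnnn1-c1ccc(Cl)cc1)c1ccccc12` gives in this assay > 50000 nM, also a limit. All three values stand at the same place, as the limit of > 50000 nM in this assay, at which 3 of the 3 values shown sit, records; compound 3 is thus indistinguishable from compound 1 and compound 2 on the numbers shown.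

Compound 4 `N#CC1=C(N)Oc2c(N)cc3nc4ccccc4nc3c2C12C(=O)N(Cc1cnnn1-c1c(F)cccc1F)c1ccccc12` differs from compound 3 by 2,6-difluorophenyl in place of 4-chlorophenyl on an aromatic nitrogen. Within the data shown here, no measured step bears directly on this exchange, and the one related aryl exchange on the same aromatic nitrogen, a step that the two limits leave unreadable from compound 1 to compound 2, is unreadable since both ends are limits. Nothing in the data points to a shift in either direction. Compound 4 is expected to give 50000 nM in this assay, with a range from 20000 nM to 120000 nM, most probably reported again only as a limit. This corresponds to an expected step of a number no higher from compound 3 to compound 4 (the limit leaves the size open), none beyond the scatter.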

Compound 4, half-maximal inhibitory concentration: > 50000 nM
Compound 4 ended at the assay's limit; the forecaster's own chance of this, stated with the estimate: 85%; the middle value sits exactly at the limit.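

No new step can be read from compound 3 to compound 4, since both results in this assay are limits and not numbers: the limit of > 50000 nM in this assay, at which 4 of the 4 values shown sit.

The compounds shown leave open whether any aryl group on this aromatic nitrogen gives a readable value in this assay.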